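Chlorophenyl hydrazides in the ovarian-cell antiproliferative series

A few compounds are considered here, and "the series" means these few. Any claim that something is new, unique, unknown or untested is made for them only; others in the source may bear on it.

Measured compounds:
compound 1, `O=C(NNc1ccccc1Cl)c1ccc(NS(=O)(=O)c2cnc(O)nc2O)cc1`, 7230 nM;
compound 2, `O=C(NNc1cccc(Cl)c1)c1ccc(NS(=O)(=O)c2cnc(O)nc2O)cc1`, 8410 nM;
compound 3, `O=C(NNc1ccccc1Cl)c1cccc(NS(=O)(=O)c2cnc(O)nc2O)c1`, 3350 nM.

All values come from a functional assay on OVCAR-3 cells (Homo sapiens) for antiproliferative activity, read by MTT assay, with a stated time of 24 h; a higher number here means a weaker inhibitor, a lower number a stronger inhibitor. Compound 3 gives the lowest number of the three, and its steps to compound 1 and compound 2 are beyond the scatter; the difference between the core of compound 3 and the core of compound 1 is not broken down here. Between compound 1 and compound 2 the change is 3-chlorophenyl in place of 2-chlorophenyl on an amine nitrogen and it made a 1.2-fold higher number from compound 1 to compound 2 (0.07 log units; within the scatter).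

Compound 4, `O=C(NNc1cccc(Cl)c1)c1cccc(NS(=O)(=O)c2cnc(O)nc2O)c1`, is not yet measured. It differs from compound 3 by 3-chlorophenyl in place of 2-chlorophenyl on an amine nitrogen, the same change as from compound 1 to compound 2, at the same place. Because a 1.2-fold higher number from compound 1 to compound 2 (0.07 log units; within the scatter) lay within the scatter, the step of a 1.2-fold higher number from compound 3 to compound 4 (0.08 log units; within the scatter) is expected to be of similar small size. Compound 4 is therefore estimated at 4000 nM, between 2000 nM and 8500 nM.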

Compound 4, half-maximal inhibitory concentration: 8040 nM
Beside the measured number, compound 4's estimate is 2.0-fold (0.30 log units) below it; measured number inside the range.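

In this assay the change to 3-chlorophenyl in place of 2-chlorophenyl on an amine nitrogen gives a 2.4-fold higher number from compound 3 to compound 4 (0.38 log units; beyond the scatter) as a modest step. Among these compounds, although only this step lies beyond the scatter, the two cores cannot be told apart in their response to the change: the same change on two cores in this assay, a 1.2-fold higher number (0.07 log units; within the scatter) from compound 1 to compound 2 and a 2.4-fold higher number (0.38 log units; beyond the scatter) from compound 3 to compound 4, 2.1-fold (0.31 log units) apart, within the scatter of two such steps. This is consistent with the change carrying over between these two cores, but a single pair of steps does not show that it carries over reliably, nor that the cores respond identically.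

Going by these compounds, what remains open is how a phenyl without chlorine, a fluorophenyl or a methoxyphenyl on the same amine nitrogen would read on either core. On these data alone, whether the change carries over to any further core also remains open.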